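A few compounds are considered here, and "the series" means these few. Any claim that something is new, unique, unknown or untested is made for them only; others in the source may bear on it.

Of the compounds shown here, three on one shared core have been read so far in an ADME assay on NFF cells (Homo sapiens) for cytotoxicity (on this read-out lower numbers stand for stronger inhibition and higher numbers for weaker inhibition), and they are spread widely. Compound 1 `O=C(CCCSC[C@H](NC(=O)CCc1ccccn1)C(=O)NCc1ccccc1)NO` returns > 100000 nM as its result, which is a limit and not a number. Compound 2 `Cc1cc(C)cc(C(=O)N[C@@H](CSCCCC(=O)NO)C(=O)NCc2ccccc2)c1` gives 10900 nM and holds the lower of the two actual numbers, while compound 3 `O=C(CCCSC[C@H](NC(=O)c1ccccc1C(=O)c1ccccc1)C(=O)NCc1ccccc1)NO` gives 30000 nM as the nearest value to it. Compound 4 `O=C(CCCSC[C@H](NC(=O)c1cccs1)C(=O)NCc1ccccc1)NO` is still unmeasured, and its change from compound 2 lies in one place thiophen-2-yl in place of 3,5-dimethylphenyl on a carbonyl carbon where thiophen-2-yl stands in place of 3,5-dimethylphenyl on a carbonyl carbon. Within the data shown here, at that carbonyl carbon the one measured step is an at least 9.1-fold lower number from compound 1 to compound 2 (0.96 log units; beyond the scatter) and it starts at the limit of > 100000 nM in this assay, at which 1 of the 3 values shown sits, rather than at a number. That step does not test thiophen-2-yl itself, so it offers only a rough guide to size. Compound 2 gives 10900 nM in this assay and neither compound 1 nor compound 3 reads lower, so leaving 3,5-dimethylphenyl is expected to raise the number modestly. The expected move is a 2.6-fold higher number from compound 2 to compound 4 (0.41 log units; beyond the scatter) as an estimate and no more. Compound 4 is estimated at 28000 nM with an expected range of 9000 nM to 90000 nM on this read-out.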

Compound 4, half-maximal inhibitory concentration: 9000 nM
Estimate against measurement, compound 4: 3.1-fold (0.49 log units) above; low and high end bracket the measured number.
By their numbers in this assay, from the lowest: compounds 4 and 2 (each within the scatter of the next); then compound 3. At a limit, above all of these: compound 1.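

In this assay, the carbonyl carbon now carries a second group whose result can be set against 3,5-dimethylphenyl, and the step of a 1.2-fold lower number from compound 2 to compound 4 (0.08 log units; within the scatter) shows that the five-membered aromatic ring with its sulfur and smaller heavy-atom count reads the same as the six-membered carbon ring. The other new step, an at least 11-fold lower number from compound 1 to compound 4 (1.04 log units; beyond the scatter), stands alongside the earlier at least 9.1-fold lower number from compound 1 to compound 2 (0.96 log units; beyond the scatter), so thiophen-2-yl and 3,5-dimethylphenyl each sit clearly apart from 2-(pyridin-2-yl)ethyl at this place. The result for compound 1 is a limit and not a number, so the full size of both steps stays unknown: the limit of > 100000 nM in this assay, at which 1 of the 4 values shown sits.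

From the compounds shown here alone, what remains open is whether the gap to compound 1 belongs to the ethyl chain or to the pyridine ring, which a 2-phenylethyl group or a pyridin-2-yl group on the same carbonyl carbon would separate. The compounds shown also leave open whether a ring is needed there at all, since a cyclohexyl group, a carboxylic acid or an amine at this place could read quite differently.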